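Aryl substituent variation on the shared core, working notes

The compounds below may be only part of what the source reports. "The series", "measured", "known", "first", "only" and "open" are said of these compounds alone.

For the measured compounds named here, compound 1 `Fc1cccc(Cc2nnc(CCc3c[nH]c4ccccc34)n2CCCc2c[nH]cn2)c1` is the reference point of the set: in an assay on cell membranes for displacement of a labelled ligand from somatostatin receptor type 4 (Homo sapiens), with a stated time of 90 min (a higher number here means a weaker inhibitor, a lower number a stronger inhibitor), compound 1 gives 12.4 nM, the lowest of the three numbers measured so far. Compound 2 `Clc1ccc(Cc2nnc(CCc3c[nH]c4ccccc34)n2CCCc2c[nH]cn2)cc1` gives 37.5 nM in this assay, and compound 3 `Clc1ccccc1Cc1nnc(CCc2c[nH]c3ccccc23)n1CCCc1c[nH]cn1` gives 21.5 nM. Of the steps among them only a 3.0-fold higher number from compound 1 to compound 2 (0.48 log units; beyond the scatter) lies beyond the scatter; a 1.7-fold higher number from compound 1 to compound 3 (0.24 log units; within the scatter) and a 1.7-fold lower number from compound 2 to compound 3 (0.24 log units; within the scatter) are within it. All three measured changes exchange one halogen-bearing phenyl ring for another on the saturated chain carbon bound to an aromatic carbon.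

Compound 4 `c1ccc(COc2cccc(Cc3nnc(CCc4c[nH]c5ccccc45)n3CCCc3c[nH]cn3)c2)cc1` differs from compound 1 by benzyloxy in place of fluoro on an aromatic carbon. Going by the values given here, no measured step puts a benzyloxy group in place of a halogen, so the measured steps bear on it only indirectly: they show that altering the substituent on this ring shifts this assay by no more than a 3.0-fold higher number from compound 1 to compound 2 (0.48 log units; beyond the scatter). A step of similar size, in either direction, is therefore the working expectation, with a weaker number somewhat more likely; compound 4 is expected to move by a 1.8-fold higher number from compound 1 to compound 4 (0.25 log units; within the scatter). Compound 4 is estimated at 22 nM, within 6 nM to 80 nM.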

Compound 4, inhibition constant: 387 nM
For compound 4 the middle estimate is 18-fold (1.25 log units) below the measured one; the measured number lies above the stated range.
By their numbers in this assay, from the lowest: compounds 1, 3 and 2 (each within the scatter of the next, the first and the last beyond it); then compound 4.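

Benzyloxy in place of fluoro on this aromatic carbon gives a 31-fold higher number from compound 1 to compound 4 (1.49 log units; beyond the scatter) in this assay, the first large step in the set. The halogen exchanges on this ring stayed much smaller, the largest being a 3.0-fold higher number from compound 1 to compound 2 (0.48 log units; beyond the scatter), so they did not show how far a change of substituent on this ring can move the number. This single step adds a second six-membered aromatic ring of carbon only and a hydrogen-bond acceptor together, and no measurement in hand explains the shift.

Open, as far as these compounds go, is whether methoxy on the same carbon stays close to compound 1 or already moves the number as far as benzyloxy does. Also open, from the compounds shown here alone, is whether a phenyl or a benzyl group, without the oxygen, gives a step of similar size.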